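Methoxy to methyl: working notes on half-life

A few compounds are considered here, and "the series" means these few. Any claim that something is new, unique, unknown or untested is made for them only; others in the source may bear on it.

In an ADME assay, at pH 3 (on this read-out higher numbers stand for a longer-lived compound and lower numbers for a shorter-lived compound), compound 1 `COc1ccnc(C[S+]([O-])c2nc3cc(OC(F)F)ccc3[nH]2)c1C` gives 0.0833 h and compound 2 `COc1ccnc(C[S+]([O-])c2nc3cc(OCC(F)(F)F)ccc3[nH]2)c1OC` gives 0.183 h. Compound 2 therefore holds the higher of the two numbers, with a gap to compound 1 that lies beyond the usual scatter.

The next structure is compound 3 `COc1ccnc(C[S+]([O-])c2nc3cc(OCC(F)(F)F)ccc3[nH]2)c1C`, which has methyl in place of methoxy on an aromatic carbon. For the measured compounds named here, no measured pair isolates this change, so any expectation rests on thin evidence. Compound 1 also carries methyl on that aromatic carbon and gives 0.0833 h, but it differs from compound 2 elsewhere as well, so its gap cannot be assigned to the methyl alone. A move towards a shorter half-life in this assay is still expected, of a size that may not clear the scatter. The expected step is a 1.7-fold lower number from compound 2 to compound 3 (0.22 log units; within the scatter). Compound 3 is estimated at 0.11 h, with an expected range of 0.06 h to 0.2 h.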

Compound 3, half-life in the ADME assay: 0.0833 h
Compound 3: the middle estimate sits 1.3-fold (0.12 log units) above what was measured, within the range that was stated.
By their numbers in the ADME assay, from the lowest: compounds 1 and 3 (each within the scatter of the next); then compound 2.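

Methyl in place of methoxy on this aromatic carbon is isolated here for the first time: in the ADME assay compound 2 gives 0.183 h and compound 3 gives 0.0833 h, and the change gives a 2.2-fold lower number from compound 2 to compound 3 (0.34 log units; beyond the scatter), so this position does register on half-life with the rest of the structure held constant. With methyl held constant, 2,2,2-trifluoroethyl in place of difluoromethyl on the oxygen leaves the ADME assay flat (no change at the digits printed from compound 1 to compound 3 (within the scatter)), so in this pair the swap on that oxygen has no visible effect on the read-out. The methoxy-to-methyl change does not register in the same way in a physicochemical assay for acid dissociation, where compound 2 gives 8.52 and compound 3 gives 8.51; the change gives a number 0.01 log units lower from compound 2 to compound 3 (within the scatter) and the two compounds stand level within the scatter.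

On these data alone, the series still rests on a single step at this position, and how half-life responds to ethoxy, a hydroxyl or an amine on that aromatic carbon remains open. Nothing at hand accounts for the half-life step between the methoxy and methyl compounds.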